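Adding a Methyl to the Ethoxy Chain of Compound 3

The source may hold more compounds than are shown below. What is called first, only, known or untested is meant among the compounds shown, and "the series" means these compounds.

Going by the values given here, compound 3 `CCOc1ccccc1OC(C)C1=NCCN1` gives 3160 nM in a functional assay on CHO cells for agonist activity at Alpha-2B adrenergic receptor (Homo sapiens) (a lower number here means that less compound is needed, a higher number that more compound is needed for the effect), the second highest of the three numbers measured so far. Compound 1 `CC(Oc1ccccc1Br)C1=NCCN1` gives 316 nM, and compound 2 `CCc1ccccc1OC(C)C1=NCCN1` gives 10000 nM. The change from compound 3 to compound 4 `CC(C)Oc1ccccc1OC(C)C1=NCCN1` is methyl in place of hydrogen on a saturated chain carbon bound to an oxygen on an aromatic ring and a saturated chain carbon. Among the compounds with values here, no measured step adds a methyl to a chain; the nearest comparisons are a 10-fold higher number from compound 1 to compound 3 (1.00 log units; beyond the scatter) and a 3.2-fold lower number from compound 2 to compound 3 (0.50 log units; beyond the scatter), which both replace the whole group on the aromatic carbon and shifted the number by modest amounts. A step of modest size, or none beyond the scatter, is therefore expected in this assay, with a somewhat higher number the more likely direction. Compound 4 is estimated at 4500 nM, with a range from 1500 nM to 13000 nM, meaning an expected step of a 1.4-fold higher number from compound 3 to compound 4 (0.15 log units; within the scatter).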

Compound 4, half-maximal effective concentration: 1740 nM
Estimate against measurement, compound 4: 2.6-fold (0.41 log units) above, and the stated range covers the measured number.
By their numbers in this assay, from the lowest: compound 1; then compounds 4 and 3 (each within the scatter of the next); then compound 2.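

In this assay, branching the ethoxy chain to isopropoxy gives a 1.8-fold lower number from compound 3 to compound 4 (0.26 log units; within the scatter), so this added methyl does not clearly separate the two compounds. Against the other groups on the aromatic carbon, isopropoxy in place of ethyl gives a 5.7-fold lower number from compound 2 to compound 4 (0.76 log units; beyond the scatter), while isopropoxy in place of bromo gives a 5.5-fold higher number from compound 1 to compound 4 (0.74 log units; beyond the scatter), so compound 1 keeps the lowest number of the four. Nothing measured here explains these differences. Going by these compounds, what a longer chain such as butoxy would do remains open, as does whether a chloro group on the aromatic carbon would match bromo.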